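The source may hold more compounds than are shown below. What is called first, only, known or untested is meant among the compounds shown, and "the series" means these compounds.

Measured compounds:
Compound 1, `Cc1ccc(SCc2ccc(/C=C/C(=O)Nc3ccccc3N)cc2)cc1`, gives in a functional assay on HeLa cells (Homo sapiens) for inhibition, read by CCK-8 assay, with a stated time of 72 h, tested at 8 uM (on this read-out higher numbers stand for more inhibition of growth at the one concentration tested and lower numbers for less inhibition of growth), a value of 21.7%.
Compound 2, `Nc1ccccc1NC(=O)c1ccc(CSc2ccc(C(F)(F)F)cn2)cc1`, gives in this assay a value of 16.5%.
Compound 3, `Cc1ccc(SCc2ccc(C(=O)Nc3ccccc3N)cc2)cc1`, gives in this assay a value of 79.2%.

Among these three, compound 3 stands highest in this assay. Its number lies above that of compound 1, the nearest of the other two, by a gap beyond the usual scatter, and further still above that of compound 2, also beyond the scatter.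

Compound 4, `Nc1ccccc1NC(=O)c1ccc(CSc2ccc(Cl)cc2)cc1`, has not yet been measured in this assay. It differs from compound 3 in one place: chloro in place of methyl on an aromatic carbon. Among the measured compounds shown here, no pair of measured compounds differs only in this way, so the measured set gives no direct reading of the change. On that basis the expected step in this assay is small, likely none beyond the scatter, with a slight lean downward. The step is estimated as a number 9.2 percentage points lower from compound 3 to compound 4 (within the scatter). Compound 4 is accordingly expected to give about 70% in this assay, within a range from 45% to 90%.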

Compound 4, percent growth inhibition at one concentration: 51.4%
The estimate for compound 4 lay 18.6 percentage points above the measured number; measured number inside the range.
By their numbers in this assay, from the lowest: compounds 2 and 1 (each within the scatter of the next); then compound 4; then compound 3.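

In this assay, among the compounds shown here, putting chloro in place of methyl on the aromatic carbon para to a large group gives a number 27.8 percentage points lower from compound 3 to compound 4 (beyond the scatter) in the only single-place comparison available here. Methyl and chloro each count as one heavy atom and add no hydrogen-bond donor or acceptor, yet the read-out still separates them, so this position is not indifferent to the group it carries. No supporting measurement accounts for the drop.

This single pair cannot show how other groups at this place would read, such as a methoxy group, an amine or a carboxylic acid. It also leaves open whether the same change would give a step of similar size on the core of compound 1 , which carries a different linker to the amide.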